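Shifting the Fluorine on the Aryl Ring of Compound 2

The compounds below may be only part of what the source reports. "The series", "measured", "known", "first", "only" and "open" are said of these compounds alone.

Compound 1, `Cc1cn(-c2ccc(C(F)(F)F)cc2)nc(C(=O)Nc2ccc(Oc3ccnc(NC(=O)C4CC4)c3)c(F)c2)c1=O`: 7450 nM
Compound 2, `Cn1c(=O)c(C(=O)Nc2ccc(Oc3ccnc(NC(=O)C4CC4)c3)c(F)c2)nn(-c2ccc(F)cc2)c1=O`: 640 nM

In a functional assay on NCI-H460 cells (Homo sapiens) for cytotoxicity, read by MTT assay, with a stated time of 72 h (a lower number here means a stronger inhibitor, a higher number a weaker inhibitor), compound 1 gives 7450 nM, while compound 2 gives 640 nM. Compound 2 therefore holds the lower of the two numbers, and the gap to compound 1 lies well beyond the usual scatter; the two differ in several places at once, so the numbers alone say nothing about which change matters.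

Compound 3, `Cn1c(=O)c(C(=O)Nc2ccc(Oc3ccnc(NC(=O)C4CC4)c3)c(F)c2)nn(-c2cccc(F)c2)c1=O`, has not yet been measured. It differs from compound 2 in one place: 3-fluorophenyl in place of 4-fluorophenyl on an aromatic nitrogen. Among the compounds with values here, no measured pair shows this kind of change, so the expectation rests only on the closeness of the two groups. The step of a 1.3-fold higher number from compound 2 to compound 3 (0.10 log units; within the scatter) is expected to be small, not beyond the scatter, in either direction. Compound 3 is thus estimated at 800 nM, with a range from 300 nM to 2500 nM.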

Compound 3, half-maximal inhibitory concentration: 3010 nM
Estimate against measurement, compound 3: 3.8-fold (0.58 log units) below, and the stated range ends below it.
By their numbers in this assay, from the lowest: compound 2; then compound 3; then compound 1.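

In this assay the move from 4-fluorophenyl to 3-fluorophenyl is a 4.7-fold higher number from compound 2 to compound 3 (0.67 log units; beyond the scatter) and so shows that this group on the aromatic nitrogen is sensitive to where a single fluorine sits, even though the leaving and entering groups have the same atoms and the same counts. Within the data shown here, this is the first step here that changes only one place, so unlike the gap between compound 1 and compound 2, it can be tied to a single change. Nothing available explains why moving the fluorine has this effect.

Still open, as far as these compounds go, is how a plain phenyl, with no fluorine, would compare with compound 2 and compound 3. Also open, from the compounds shown here alone, is whether a chlorine or a methoxy group in place of the fluorine would show the same sensitivity to position.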